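Methyl for Methoxy on a Nucleoside Core

A few compounds are considered here, and "the series" means these few. Any claim that something is new, unique, unknown or untested is made for them only; others in the source may bear on it.

Compound 1 `COc1ncnc2c1c(I)cn2[C@@H]1O[C@H](CO)[C@@H](O)[C@H]1O` is the anchor of this comparison. In an ADME assay on BJ cells (Homo sapiens), read by MTT assay, with a stated time of 72 h (a higher number here means a weaker inhibitor, a lower number a stronger inhibitor), compound 1 gives 91000 nM, which stands at the top of the two plain numbers shown, although its nearest neighbour is within the scatter. Compound 3 `COc1ncnc2c1c(-c1ccsc1)cn2[C@@H]1O[C@H](CO)[C@@H](O)[C@H]1O` gives 64300 nM, and the step of a 1.4-fold lower number from compound 1 to compound 3 (0.15 log units; within the scatter) is too small to count as a change. Compound 2 `COc1ncnc2c1c(-c1ccccc1)cn2[C@@H]1O[C@H](CO)[C@@H](O)[C@H]1O` reaches only a limit of this assay, > 100000 nM, as noted by the limit of > 100000 nM in this assay, at which 1 of the 3 values shown sits.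

Compound 4 `Cc1ncnc2c1c(I)cn2[C@@H]1O[C@H](CO)[C@@H](O)[C@H]1O` has not yet been measured. Its change from compound 1 is methyl in place of methoxy on an aromatic carbon. Every measured step, an at least 1.0-fold higher number from compound 1 to compound 2 (0.04 log units; that floor lies within the scatter), a 1.4-fold lower number from compound 1 to compound 3 (0.15 log units; within the scatter) and an at least 1.5-fold lower number from compound 2 to compound 3 (0.19 log units; that floor lies within the scatter), concerns the iodo position and leaves the methoxy untouched, so none bears directly on this change, and all of them sat within the scatter. A step beyond the scatter is therefore not expected here either, and the expected step is a 1.0-fold lower number from compound 1 to compound 4 (0.00 log units; within the scatter). Compound 4 is estimated at 90000 nM, with a range from 40000 nM to 200000 nM.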

Compound 4, half-maximal inhibitory concentration: > 100000 nM
Compound 4 gave a limit, no number; the forecaster's own chance of this, stated with the estimate: 35%; at least 1.1-fold (0.04 log units) between middle value and limit.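

Within the data shown here, this is the first step that touches the methoxy rather than the iodo position. In this assay compound 4 gives > 100000 nM, which is a limit of the assay and not a number. Methyl in place of methoxy thus gives an at least 1.0-fold higher number from compound 1 to compound 4 (0.04 log units; that floor lies within the scatter), so a lower number at this position is not seen, but the true size of the step cannot be read, and compound 4 now stands with compound 2 at the same limit: the limit of > 100000 nM in this assay, at which 2 of the 4 values shown sit.

From the compounds shown here alone, what an amine or a longer chain such as ethoxy would do in place of the methoxy stays open. Also open, going by these compounds, is whether methyl would give the same reading with phenyl or thiophen-3-yl in place of the iodo.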